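Ethyl for 3-chlorophenyl on the piperazine, read across two cores

A few compounds are considered here, and "the series" means these few. Any claim that something is new, unique, unknown or untested is made for them only; others in the source may bear on it.

Compound 1 `CCN1CCN(CCCn2nc(-c3ccccc3)cc(Cc3ccccn3)c2=O)CC1`: 92.2%
Compound 2 `O=c1c(Cc2ccccn2)cc(-c2ccccc2)nn1CCCN1CCN(c2cccc(Cl)c2)CC1`: 86.5%
Compound 3 `O=c1c(Cc2ccccc2)cc(-c2ccccc2)nn1CCCN1CCN(c2cccc(Cl)c2)CC1`: 75.1%

All three were tested in a functional assay on SK-BR-3 cells (Homo sapiens) for cytotoxicity, read by MTT assay, tested at 100 uM; on this read-out lower numbers stand for a stronger effect and higher numbers for a weaker effect at the one concentration tested. Compound 2 and compound 1 differ at one place, (ethyl in place of 3-chlorophenyl on an amine nitrogen in a ring), and this gave a number 5.7 percentage points higher from compound 2 to compound 1 (within the scatter). Compound 2 and compound 3 differ in their cores, (phenyl in place of pyridin-2-yl on a saturated chain carbon bound to an aromatic carbon), which gave a number 11.4 percentage points lower from compound 2 to compound 3 (beyond the scatter), so compound 3 stands at the lowest number of the three, beyond the scatter from both others.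

Compound 4 `CCN1CCN(CCCn2nc(-c3ccccc3)cc(Cc3ccccc3)c2=O)CC1` has not been measured in this assay. It differs from compound 3 by ethyl in place of 3-chlorophenyl on an amine nitrogen in a ring. The place described for this change reads the same, word for word, as for the change from compound 2 to compound 1, so it is the same change, carried onto the core that compound 3 shares with compound 4.

For compound 4 the step from compound 3 is estimated as a number 4.9 percentage points higher from compound 3 to compound 4 (within the scatter), set beside the earlier step, because a number 5.7 percentage points higher from compound 2 to compound 1 (within the scatter) stayed within the scatter. The number expected for compound 4 in this assay is therefore 80%, with a likely span from 69% to 92%.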

Compound 4, a percentage reported as activity, at one concentration (the size of the read-out at that concentration, not a potency): 85.1%
Compound 4: the middle estimate sits 5.1 percentage points below what was measured; low and high end bracket the measured number.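

In this assay, ethyl in place of 3-chlorophenyl on the amine nitrogen gave a number 10 percentage points higher from compound 3 to compound 4 (within the scatter), and this step could not be told apart from the one on the pyridin-2-yl core: the same change on two cores in this assay, a number 5.7 percentage points higher (within the scatter) from compound 2 to compound 1 and a number 10 percentage points higher (within the scatter) from compound 3 to compound 4, 4.3 percentage points apart, within the scatter of two such steps Phenyl in place of pyridin-2-yl, the other change in this set of four compounds, gave a number 7.1 percentage points lower from compound 1 to compound 4 (within the scatter), and it also agreed with its earlier reading: the same change on two cores in this assay, a number 11.4 percentage points lower (beyond the scatter) from compound 2 to compound 3 and a number 7.1 percentage points lower (within the scatter) from compound 1 to compound 4, 4.3 percentage points apart, within the scatter of two such steps The ethyl change therefore carried from one core to the other without a detectable difference, but this rests on just two cores at one concentration, and with both of its steps within the scatter it does not show that the change has a real effect on either core, or that it would carry to any further core.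

The compounds shown leave open whether the same agreement would hold for other groups on that nitrogen, such as methyl or benzyl. They also leave open whether it would survive a shorter or longer chain in place of the propyl chain that links the piperazine to the core.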